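This account rests on a few compounds, and the source may have more. Where it says the series, first, only, none or still open, it means among the compounds named here.

Compound 2, with the structure `CC(C)[C@H](NC(=O)COc1cccc2ccccc12)C(=O)N[C@@H](CC(=O)O)C(=O)COn1nnc2ccccc21`, belongs to a small set tested in a functional assay on Jurkat cells (Homo sapiens) for inhibition; on this read-out higher numbers stand for weaker inhibition and lower numbers for stronger inhibition. In this assay compound 2 gives > 200000 nM, which is a limit of the assay and not a measured number. Within the data shown here, compound 1, with the structure `CC(C)[C@H](NC(=O)COc1cccc2ccccc12)C(=O)N[C@@H](CC(=O)O)C(=O)CSc1nc2ccccc2[nH]1`, is the only other measured compound. In this assay compound 1 gives > 200000 nM, again a limit rather than a number. The step that the two limits leave unreadable from compound 1 to compound 2 therefore cannot be read because both values sit at the limit of > 200000 nM in this assay, at which 2 of the 2 values shown sit. Compound 3, with the structure `CC(C)[C@H](NC(=O)COc1cccc2ccccc12)C(=O)N[C@@H](CC(=O)O)C(=O)COc1ccc2ccccc2n1`, has not yet been measured. It differs from compound 2 in one place: a group of 10 heavy atoms (9 carbon, 1 nitrogen; one six-membered aromatic ring of carbon only, one six-membered aromatic ring with 1 hetero atom) in place of a group of 9 heavy atoms (6 carbon, 3 nitrogen; one five-membered aromatic ring with 3 hetero atoms, one six-membered aromatic ring of carbon only), on an oxygen on a saturated carbon. Among the measured compounds shown here, no measured step bears on this change, since the only step available is unreadable, so there is nothing to suggest a gain or loss in inhibition beyond the scatter. Compound 3 is therefore expected to give about 200000 nM, within a range from 50000 nM to 400000 nM. The step of a number no higher from compound 2 to compound 3 (the limit leaves the size open) that this estimate means is expected to stay within the usual scatter, with a good chance that only a limit is reported again.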

Compound 3, half-maximal inhibitory concentration: > 200000 nM
Compound 3: only a limit was reported; the forecaster's own chance of this, stated with the estimate: 70%; the middle value lies on the limit itself.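

Compound 3 again gives only a limit in this assay, so no step among compound 1, compound 2 and compound 3 can be read: the limit of > 200000 nM in this assay, at which 3 of the 3 values shown sit.

The compounds shown leave open how strongly any of the three inhibits in this assay, and whether exchanging the group that differs among them changes inhibition at all.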